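The source may hold more compounds than are shown below. What is called first, only, known or untested is meant among the compounds shown, and "the series" means these compounds.

Measured so far in a physicochemical assay for solubility, with a stated time of 18 h, at pH 7.4; a higher number here means a more soluble compound, a lower number a less soluble compound: compound 1 `COc1ccc(F)cc1CNCCCNc1ccnc2cc(Cc3cc(C)cc(C)c3)ccc12` gives 4200 nM; compound 2 `COc1ccc(F)cc1CNCCCNc1ccnc2cc(-c3ccc(C(C)(C)C)cc3)ccc12` gives 32000 nM.

Within the data shown here, compound 2 stands as the higher of the two, because the one measured step, a 7.6-fold higher number from compound 1 to compound 2 (0.88 log units; beyond the scatter), lies beyond the scatter. Compound 3 `COc1ccc(F)cc1CNCCCNc1ccnc2cc(Oc3ccccc3OC)ccc12` differs from compound 2 by 2-methoxyphenoxy in place of 4-(tert-butyl)phenyl on an aromatic carbon. Among the measured compounds shown here, the single measured step also exchanged the group at this same place and was modest in size, but it swapped different groups, so it offers only a rough guide. On that basis a further modest rise is expected, a 1.9-fold higher number from compound 2 to compound 3 (0.27 log units; within the scatter). Compound 3 is expected to give about 60000 nM, within a range from 15000 nM to 200000 nM.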

Compound 3, solubility: 14500 nM
For compound 3 the middle estimate is 4.1-fold (0.62 log units) above the measured one; the whole stated range lies above it.
By their numbers in this assay, from the lowest: compound 1; then compound 3; then compound 2.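

In this assay, 2-methoxyphenoxy brings 2 hydrogen-bond acceptors where 4-(tert-butyl)phenyl has 0, yet the change gives a 2.2-fold lower number from compound 2 to compound 3 (0.34 log units; beyond the scatter) and not a rise. Against 3,5-dimethylbenzyl, the same group gives a 3.5-fold higher number from compound 1 to compound 3 (0.54 log units; beyond the scatter) and so places compound 3 in the middle of the three, showing that this position separates all three groups by more than the scatter. Nothing available here explains this order.

Going by these compounds, whether the order extends to other groups here, such as an amine or a carboxylic acid, stays open. So does the separate contribution of the methoxy group and the ring oxygen of 2-methoxyphenoxy.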